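The source may report more compounds than this note shows. Statements on the series, on what has been measured and on what is new or still open speak of the compounds shown alone.

In an assay on HeLa cells with Bile acid receptor (Homo sapiens) as the target, read by a luciferase reporter, with a stated time of 24 h (on this read-out higher numbers stand for an effect only at larger amounts of compound and lower numbers for an effect already at smaller amounts), compound 1 `CN(C)C(=O)c1ccc(CNC(=O)c2ccc(C(C)(C)C)cc2)cc1` gives 170 nM. Compound 2 `Cc1ccc(C(=O)NCc2ccc(C(=O)O)cc2)cc1C` gives 320 nM in this assay, and the two numbers lie within the scatter of each other, so neither compound stands apart from the other on these data. Compound 3 `CC(=O)c1ccc(CNC(=O)c2ccc(C(C)(C)C)cc2)cc1` has not yet been measured in this assay. It differs from compound 1 in one place: methyl in place of dimethylamino on a carbonyl carbon. Among the compounds with values here, no measured pair here shows what this exchange does, so the expected outcome is a 1.3-fold higher number from compound 1 to compound 3 (0.11 log units; within the scatter), a step that stays within the scatter in either direction. Compound 3 is accordingly estimated to give 220 nM, in a range from 70 nM to 700 nM.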

Compound 3, half-maximal effective concentration: 100 nM
Estimate against measurement, compound 3: 2.2-fold (0.34 log units) above, and the stated range covers the measured number.
By their numbers in this assay, from the lowest: compounds 3, 1 and 2 (each within the scatter of the next, the first and the last beyond it).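

In this assay, the exchange of dimethylamino for methyl on a carbonyl carbon, which turns dimethylcarbamoyl into acetyl, gives a 1.7-fold lower number from compound 1 to compound 3 (0.23 log units; within the scatter). This first pair at this position shows that the dimethylamino group can be replaced by methyl without a change that stands clear of the scatter, so the dimethylamino group is not needed to keep a number of this size. Nothing given here explains the step.

The compounds shown leave open how a longer chain such as ethyl or propyl, or an amine such as methylamino, would behave on this carbonyl carbon. They also leave open whether the position keeps such numbers once the carbonyl itself is replaced, for instance by a nitrile.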